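Cyano for Methoxy on the Pyrazole of a Glucagon Antagonist

A few compounds are considered here, and "the series" means these few. Any claim that something is new, unique, unknown or untested is made for them only; others in the source may bear on it.

Going by the values given here, compound 1 `CCCC(Oc1ccc(-n2cc(OC)cn2)cc1)c1ccc(C(=O)NCCC(=O)O)cc1` is one of two compounds measured in a functional assay on cells for antagonist activity at Glucagon receptor (Homo sapiens), read by cAMP accumulation, in the presence of a further agent that is not named here; on this read-out higher numbers stand for weaker inhibition and lower numbers for stronger inhibition. Going by these compounds, compound 1 gives only a limit there, > 23000 nM, so it sits at the limit of > 23000 nM in this assay, at which 1 of the 2 values shown sits, and its true position is unknown. The second compound, compound 2 `O=C(O)CCNC(=O)c1ccc(C(Oc2ccc(-n3cc(C(F)(F)F)cn3)cc2)C2CCC2)cc1`, carries a cyclobutyl and a trifluoromethyl instead, and in this assay compound 2 gives 3000 nM. The unmeasured compound 3 `CCCC(Oc1ccc(-n2cc(C#N)cn2)cc1)c1ccc(C(=O)NCCC(=O)O)cc1` keeps the core of compound 1 and changes one group: cyano in place of methoxy on an aromatic carbon. Among the compounds with values here, no measured pair isolates this change, and compound 2 differs from compound 1 in more than one place, so it is not a guide to the size of this step. A gain in potency is expected, of the size an at least 2.3-fold lower number from compound 1 to compound 3 (0.36 log units; beyond the scatter), though it could also be nothing beyond the scatter. Compound 3 is therefore estimated at 10000 nM, with a range from 2500 nM to 40000 nM.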

Compound 3, antagonist equilibrium constant: > 50000 nM
Compound 3 ended at the assay's limit; the forecaster's own chance of this, stated with the estimate: 40%; middle value at least 5.0-fold (0.69 log units) from the limit.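

Going by these compounds alone, compound 1 and compound 3 both give only limits in this assay, so no step between them can be read. The compounds shown leave open whether cyano in place of methoxy changes the inhibition at all, and in which direction.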